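The source may hold more compounds than are shown below. What is called first, only, known or untested is meant among the compounds shown, and "the series" means these compounds.

In an assay on HEK293F cells for inhibition of cholesterol 24-hydroxylase (Homo sapiens), read by trypan blue exclusion, with stated times of 15 min and 5 h (a lower number here means a stronger inhibitor, a higher number a weaker inhibitor), compound 3 `CN(C)C(=O)C1CCN(c2cnccc2-n2cccn2)CC1` gives 48 nM. On the numbers shown it stands second highest of three; its nearest neighbour is compound 2 `CN(C)C(=O)C1CCN(c2cnccc2-c2ccccn2)CC1`, which gives 68 nM, and the furthest is compound 1 `CN(C)C(=O)C1CCN(c2cncnc2-c2ccccc2)CC1`, which gives 16 nM. Compound 4 `Cc1ccn(-c2ccncc2N2CCC(C(=O)N(C)C)CC2)n1` differs from compound 3 by methyl in place of hydrogen on an aromatic carbon; cut one bond further out, the change reads 1H-pyrazol-1-yl to 3-methyl-1H-pyrazol-1-yl, the methyl sitting next to the ring nitrogen and two ring bonds from the ring atom that bears a large group. Going by the values given here, the only measured step at this end of the molecule is a 1.4-fold lower number from compound 2 to compound 3 (0.15 log units; within the scatter), and it exchanges one ring for another rather than adding a methyl to a ring that stays in place, so no measured step tells how a methyl on this carbon is taken. Among the compounds with values here, nothing among the measured compounds points to a change beyond the scatter, and the expected step is therefore small, a 1.2-fold lower number from compound 3 to compound 4 (0.08 log units; within the scatter). Compound 4 is estimated at 40 nM in this assay, with a range from 15 nM to 110 nM.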

Compound 4, half-maximal inhibitory concentration: 1100 nM
Compound 4: middle estimate off by 28-fold (1.44 log units), on the low side, outside the stated range (above it).
By their numbers in this assay, from the lowest: compound 1; then compounds 3 and 2 (each within the scatter of the next); then compound 4.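

In this assay, going by these compounds alone, a methyl in place of hydrogen on this carbon, next to the ring nitrogen, gives a 23-fold higher number from compound 3 to compound 4 (1.36 log units; beyond the scatter), so a position left bare in the earlier compounds turns out to be highly sensitive to a single added heavy atom. The exchange of pyridin-2-yl for 1H-pyrazol-1-yl had stayed within the scatter, yet 3-methyl-1H-pyrazol-1-yl in the same place gives a 16-fold higher number from compound 2 to compound 4 (1.21 log units; beyond the scatter), so the ring exchange alone gave no warning of this loss. Nothing measured here accounts for the loss.

The compounds shown leave open whether a fluorine or a hydroxymethyl on this carbon would be taken as poorly as methyl. They also leave open whether a methyl on the other carbons of the five-membered ring would cost as much.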